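The compounds below may be only part of what the source reports. "The series", "measured", "known", "first", "only" and "open" are said of these compounds alone.

Compound 1, `Cc1nn(C)c2c1C(c1cccc(Cl)c1)=NCCN2`, is tested in a functional assay on the whole organism for positive allosteric modulation, with Rattus norvegicus as the target (a higher number here means that more compound is needed for the effect, a lower number that less compound is needed), where compound 1 gives 0.63 mg/kg. Its companion, compound 2, `CC(=O)N1CCN=C(c2cccc(Cl)c2)c2c(C)nn(C)c21`, carries an acetyl in place of hydrogen on a nitrogen on an aromatic ring in a ring. For compound 2 this assay records only a limit, > 10 mg/kg. The step of an at least 15-fold higher number from compound 1 to compound 2 (1.20 log units; beyond the scatter) rests on that limit, (the limit of > 10 mg/kg in this assay, at which 1 of the 2 values shown sits). Within the data shown here, compound 1 therefore holds the only actual number among the values recorded here. Compound 3, `Cc1nn(C)c2c1C(c1cccc([N+](=O)[O-])c1)=NCCN2`, departs from compound 1 at a different place: nitro in place of chloro on an aromatic carbon. Among the measured compounds shown here, the one measured step touches the nitrogen that receives the acetyl, not the aromatic carbon that receives the nitro group, so no measured step bears on this change. With nothing pointing either way, the step of a 1.6-fold higher number from compound 1 to compound 3 (0.20 log units; within the scatter) is expected to remain within the scatter. For compound 3 the estimate is 1 mg/kg, with a range from 0.3 mg/kg to 3 mg/kg.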

Compound 3, minimum effective dose: 5 mg/kg
Estimate against measurement, compound 3: 5.0-fold (0.70 log units) below; the measured number lies above the stated range.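

With nitro in place of chloro on the aromatic carbon, this assay shows a 7.9-fold higher number from compound 1 to compound 3 (0.90 log units; beyond the scatter), so this position on the six-membered aromatic ring of carbon only is not indifferent to what it carries. Among these compounds, until now, the only change with a reading beyond the scatter lay on the nitrogen that takes the acetyl; this result shows that a change elsewhere on the core of compound 1 also means more compound is needed for the effect. Nothing recorded here accounts for the step.

The compounds shown leave open whether chloro itself is favoured at this carbon or whether other groups, such as fluoro, methoxy or an amine, would keep the number near that of compound 1. They also leave open whether the hydrogen-bond acceptors that enter with nitro have any part in the change.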